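The source may report more compounds than this note shows. Statements on the series, on what has been measured and on what is new or still open speak of the compounds shown alone.

Compound 1 `Oc1nc2nonc2nc1Nc1ccc(S(F)(F)(F)(F)F)cc1`, tested in an assay on mitochondria from L6 cells (Rattus norvegicus) for activation, with a stated time of 90 min (a lower number here means that less compound is needed, a higher number that more compound is needed for the effect), gives 3900 nM. That is the lowest of the three numbers recorded, but compound 2 `Cc1cc(OC(F)(F)F)ccc1Nc1nc2nonc2nc1O` gives 4600 nM and compound 3 `Oc1nc2nonc2nc1Nc1cccc(OC(F)(F)F)c1` gives 5100 nM, and both lie within the scatter of compound 1, so the three compounds cannot be ordered. Going by the values given here, no step between measured compounds that differ in a single place exists here. Compound 4 `Oc1nc2nonc2nc1Nc1ccc(OC(F)(F)C(F)F)cc1` differs from compound 1 by a group of 7 heavy atoms (2 carbon, 1 oxygen, 4 fluorine; no ring) in place of a group of 6 heavy atoms (5 fluorine, 1 sulfur; no ring), on an aromatic carbon. Because compound 2 and compound 3 remain within the scatter of compound 1 at 3900 nM, no step beyond the scatter is expected in either direction. Compound 4 is therefore expected to give 4500 nM, between 2000 nM and 10000 nM. The expected step of a 1.2-fold higher number from compound 1 to compound 4 (0.06 log units; within the scatter) stays within the scatter.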

Compound 4, half-maximal effective concentration: 7000 nM
For compound 4 the middle estimate is 1.6-fold (0.19 log units) below the measured one; low and high end bracket the measured number.
By their numbers in this assay, from the lowest: compounds 1, 2, 3 and 4 (each within the scatter of the next).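

In this assay, the exchange of the sulfur-bearing fluorinated group for 1,1,2,2-tetrafluoroethoxy on this aromatic carbon gives a 1.8-fold higher number from compound 1 to compound 4 (0.25 log units; within the scatter). Going by these compounds alone, this is the first step that can be read at this position, and it shows that this exchange, which adds one hydrogen-bond acceptor, leaves the number within the scatter. Nothing given here explains this result. From the compounds shown here alone, whether an amine, a methoxy group or a carboxylic acid at this position would also stay within the scatter remains open. So does the effect of changing the shared core.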